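The compounds below may be only part of what the source reports. "The series", "measured", "known", "first", "only" and "open" are said of these compounds alone.

Compound 1 `Cc1cc(N2CC[C@@H](C)[C@@H](N(C)c3ncnc4[nH]ccc34)C2)n2nc(SCc3csc4ccc(Cl)cc34)nc2n1`: > 100000 nM, a limit of the assay
Compound 2 `Cc1cc(N2CC[C@@H](C)[C@@H](N(C)c3ncnc4[nH]ccc34)C2)n2nc(SCC3CCCCC3)nc2n1`: 16300 nM
Compound 3 `C=CCSc1nc2nc(C)cc(N3CC[C@@H](C)[C@@H](N(C)c4ncnc5[nH]ccc45)C3)n2n1`: 40900 nM

These results come from a functional assay on BGC-823 cells (Homo sapiens) for inhibition, read by MTT assay, with a stated time of 72 h; a lower number here means a stronger inhibitor, a higher number a weaker inhibitor. Compound 3 holds the higher of the two exact numbers, and compound 2 is its nearest neighbour. Compound 1 has only a limit, (the limit of > 100000 nM in this assay, at which 1 of the 3 values shown sits).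

Compound 4 `Cc1ccc(CSc2nc3nc(C)cc(N4CC[C@@H](C)[C@@H](N(C)c5ncnc6[nH]ccc56)C4)n3n2)cc1` changes one group of compound 3: 4-methylphenyl in place of vinyl on a saturated chain carbon bound to a sulfur. Two measured steps at this same place bear on the change, and they point in opposite directions. Swapping cyclohexyl for vinyl gave a 2.5-fold higher number from compound 2 to compound 3 (0.40 log units; beyond the scatter), so vinyl was the worse of those two groups. Swapping 5-chloro-1-benzothiophen-3-yl for vinyl gave an at least 2.4-fold lower number from compound 1 to compound 3 (0.38 log units; beyond the scatter), so vinyl was the better of those two. The new group is aromatic like the group in compound 1, yet smaller, so these steps give no clear direction. The expected result is a 1.2-fold lower number from compound 3 to compound 4 (0.07 log units; within the scatter), which means no real change is anticipated. For compound 4 the estimated value is 35000 nM, with an expected range from 10000 nM to 100000 nM.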

Compound 4, half-maximal inhibitory concentration: 69500 nM
The estimate for compound 4 lay 2.0-fold (0.30 log units) below the measured number; the range from low to high includes it.
By their numbers in this assay, from the lowest: compound 2; then compounds 3 and 4 (each within the scatter of the next). At a limit, above all of these: compound 1.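

In this assay, swapping vinyl for 4-methylphenyl on a saturated chain carbon bound to a sulfur gives a 1.7-fold higher number from compound 3 to compound 4 (0.23 log units; within the scatter) and so does not separate the two groups, even though the entering group adds a six-membered aromatic ring. Against cyclohexyl, the same group gives a 4.3-fold higher number from compound 2 to compound 4 (0.63 log units; beyond the scatter), which shows that a six-membered ring alone does not reproduce the lower number of compound 2. The step from the 5-chloro-1-benzothiophen-3-yl group rests on a limit of the assay, reads an at least 1.4-fold lower number from compound 1 to compound 4 (0.15 log units; that floor lies within the scatter) and sets no order between the groups: the limit of > 100000 nM in this assay, at which 1 of the 4 values shown sits.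

From the compounds shown here alone, it remains open how an amine or a carboxylic acid at this place would read in this assay. Also open, going by these compounds, is whether plain phenyl would differ from 4-methylphenyl, and whether a longer chain ending in cyclohexyl would go lower than compound 2.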